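This account rests on a few compounds, and the source may have more. Where it says the series, first, only, none or still open, it means among the compounds named here.

Measured so far in a functional assay on SNB-19 cells (Homo sapiens) for inhibition, read by sulforhodamine B assay, with a stated time of 48 h; a lower number here means a stronger inhibitor of growth, a higher number a weaker inhibitor of growth:
- compound 1 `NS(=O)(=O)c1ccc(Nc2nc(N/N=C/c3ccc(C(F)(F)F)cc3)nc(Nc3ccccc3)n2)cc1`: 3460 nM
- compound 2 `Cc1nn(-c2ccccc2)cc1/C=N/Nc1nc(Nc2ccccc2)nc(Nc2ccc(S(N)(=O)=O)cc2)n1`: 3440 nM

Going by the values given here, compound 2 stands at the lowest of the two numbers, but its only neighbour is compound 1 at a 1.0-fold lower number from compound 1 to compound 2 (0.00 log units; within the scatter), within the scatter, so the two compounds cannot be ordered against each other. That single step exchanged the ring carried on the carbon with a double bond to nitrogen, a six-membered aromatic ring of carbon only for a five-membered aromatic ring with two hetero atoms plus a phenyl, and the number did not move.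

Compound 3 `NS(=O)(=O)c1ccc(Nc2nc(N/N=C/c3ccccn3)nc(Nc3ccccc3)n2)cc1` carries the change (pyridin-2-yl in place of 3-methyl-1-phenyl-1H-pyrazol-4-yl on a carbon with a double bond to nitrogen). Among the compounds with values here, the one step that bears on it is the same exchange at the same carbon, a 1.0-fold lower number from compound 1 to compound 2 (0.00 log units; within the scatter), which left the number flat. On that basis the step from compound 2 to compound 3 is expected to stay within the scatter as well, with no direction favoured: a 1.0-fold higher number from compound 2 to compound 3 (0.01 log units; within the scatter). Within the data shown here, a smaller ring with fewer heavy atoms enters here, and the one measured step gives no hint of how such a reduction acts, so the range is kept wide. Compound 3 is therefore estimated at 3500 nM, within 1400 nM to 9000 nM.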

Compound 3, concentration for 50% growth inhibition: 850 nM
For compound 3 the middle estimate is 4.1-fold (0.61 log units) above the measured one, outside the stated range (below it).
By their numbers in this assay, from the lowest: compound 3; then compounds 2 and 1 (each within the scatter of the next).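

At the carbon with a double bond to nitrogen, the number in this assay does respond to the ring carried there: the move to pyridin-2-yl gives a 4.0-fold lower number from compound 2 to compound 3 (0.61 log units; beyond the scatter) and, from the other earlier group, a 4.1-fold lower number from compound 1 to compound 3 (0.61 log units; beyond the scatter) even though the exchange between those two earlier groups had left the number flat. Compound 3 is the only one of the three whose steps to both others lie beyond the scatter, so the position is not indifferent to its substituent, though the size of the steps remains modest. A ring nitrogen alone does not separate the compounds, since compound 2 also carries ring nitrogens at this carbon and stays level with compound 1, and nothing at hand explains the shift.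

The step from 3-methyl-1-phenyl-1H-pyrazol-4-yl, with 12 heavy atoms, to pyridin-2-yl, with 6, changes ring type and heavy-atom count together, so the compounds shown cannot separate the two. Still open, going by these compounds, is how plain phenyl, pyridin-3-yl, pyridin-4-yl or a saturated amine such as piperidin-4-yl would compare with pyridin-2-yl on the same carbon.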